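The source may report more compounds than this note shows. Statements on the series, on what has been measured and on what is new or still open speak of the compounds shown alone.

In an assay on cells for inhibition of Amine oxidase [flavin-containing] B (Homo sapiens), read by Amplex Red, with a stated time of 30 min (on this read-out lower numbers stand for stronger inhibition and higher numbers for weaker inhibition), three compounds of the shared core have been measured. Compound 1 `O=C1COC(c2ccc(NC(=O)Nc3cccc(Cl)c3)cc2)=NN1` gives 2890 nM, and compound 2 `O=C1COC(c2ccc(/N=C/c3ccc(Cl)cc3)cc2)=NN1` gives 433 nM. Compound 3 `O=C1COC(c2ccc(/C=C/c3cccc(F)c3)cc2)=NN1` gives 22 nM, the lowest of the three numbers; its nearest neighbour is compound 2, whose number lies beyond the scatter above it, and compound 1 stands furthest away. Compound 4 `Cc1cccc(/C=C/c2ccc(C3=NNC(=O)CO3)cc2)c1` has not yet been measured in this assay. It differs from compound 3 by methyl in place of fluoro on an aromatic carbon. Among the measured compounds shown here, no pair of measured compounds that differ only in this way is available, so the size of the step cannot be read from the data. Given that compound 3 gives 22 nM and the change exchanges one single heavy atom for another without altering donors, acceptors or charge, the step from compound 3 to compound 4 is expected to be small, a 1.4-fold higher number from compound 3 to compound 4 (0.13 log units; within the scatter), and not clearly beyond the scatter. Compound 4 is therefore estimated at 30 nM in this assay, with a likely range from 8 nM to 120 nM.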

Compound 4, half-maximal inhibitory concentration: 338 nM
The estimate for compound 4 lay 11-fold (1.05 log units) below the measured number; the measured number lies above the stated range.
By their numbers in this assay, from the lowest: compound 3; then compounds 4 and 2 (each within the scatter of the next); then compound 1.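

In this assay, the change from 3-fluorophenyl to 3-methylphenyl gives a 15-fold higher number from compound 3 to compound 4 (1.19 log units; beyond the scatter), even though one heavy atom replaces another and the counts of donors, acceptors and charge stay the same. This is the first step shown that isolates a single place, and it reveals that the number is highly sensitive to the group on this aromatic carbon, meta to a large group. No measurement at hand explains the size of this step.

The compounds shown leave open where hydrogen, chloro, methoxy or an amine at this place would fall relative to compound 3 and compound 4. They also leave open whether the same exchange would produce a step of similar size with the linking groups of compound 1 or compound 2.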